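Trifluoromethyl on a saturated ring carbon, carried across two cores

The source may hold more compounds than are shown below. What is called first, only, known or untested is meant among the compounds shown, and "the series" means these compounds.

Measured in an assay on HEK293 cells for binding affinity to Free fatty acid receptor 1 (Homo sapiens), read by scintillation counting and radioligand binding, with a stated time of 1 h; a higher number here means a weaker inhibitor, a lower number a stronger inhibitor:
compound 1 `Cc1ccccc1Oc1ccc(N2C[C@@H](C(F)(F)F)C[C@H]2CC(=O)O)cc1`: 35 nM
compound 2 `Cc1ccccc1Oc1ccc(N2CCC[C@H]2CC(=O)O)cc1`: 4400 nM
compound 3 `COc1ccc(F)c(-c2ccc(Cc3ccc(N4CCC[C@H]4CC(=O)O)cc3)c(C)c2)c1`: 310 nM

Within this assay the step of a 130-fold lower number from compound 2 to compound 1 (2.10 log units; beyond the scatter) comes from one change, (trifluoromethyl in place of hydrogen on a saturated ring carbon). Compound 3 carries a different core; how its core differs from that of compound 2 is not broken down here, and compound 3 sits between the two in this assay. Compound 4 `COc1ccc(F)c(-c2ccc(Cc3ccc(N4C[C@@H](C(F)(F)F)C[C@H]4CC(=O)O)cc3)c(C)c2)c1` is not yet measured; it differs from compound 3 by trifluoromethyl in place of hydrogen on a saturated ring carbon, the same change as from compound 2 to compound 1, at a place described in the same words. For compound 4 a step of a 39-fold lower number from compound 3 to compound 4 (1.59 log units; beyond the scatter) is expected in this assay, resting on the size of a 130-fold lower number from compound 2 to compound 1 (2.10 log units; beyond the scatter) and discounted somewhat, since the change is seen only once and on another core. Compound 4 is accordingly estimated at 8 nM, with a range from 2 nM to 40 nM.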

Compound 4, inhibition constant: 45 nM
Compound 4: the middle estimate sits 5.6-fold (0.75 log units) below what was measured, and the stated range ends below it.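

In this assay, trifluoromethyl in place of hydrogen on a saturated ring carbon again lowers the number on the second core, a 6.9-fold lower number from compound 3 to compound 4 (0.84 log units; beyond the scatter), so the direction of the step carries over between these two cores. Its size does not carry over, and the two steps differ: the same change on two cores in this assay, a 130-fold lower number (2.10 log units; beyond the scatter) from compound 2 to compound 1 and a 6.9-fold lower number (0.84 log units; beyond the scatter) from compound 3 to compound 4, 18-fold (1.26 log units) apart, beyond the scatter of two such steps

Two pairs of compounds give no rule for further cores and no reason for the gap, so a step seen on one core here is a guide to direction only, not to size.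

Still open, going by these compounds, is whether a methyl group or a single fluorine at that ring carbon would give a step of the same direction. Also open, on these data alone, is whether the trifluoromethyl step would hold with a longer chain in place of the carboxymethyl group.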